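Swapping phenyl for bromothiophene on the sulfonyl sulfur

The compounds below may be only part of what the source reports. "The series", "measured", "known", "first", "only" and "open" are said of these compounds alone.

Compound 1 `O=C1C=CC2(C=C1)OCC(=O)N2S(=O)(=O)c1ccccc1`: > 10000 nM (a limit)
Compound 2 `O=C1C=CC2(C=C1)OCC(=O)N2S(=O)(=O)c1ccc(N2CCCC2=O)cc1`: > 10000 nM (a limit)

In a functional assay on MDA-MB-231 cells (Homo sapiens) for inhibition, read by sulforhodamine B assay, with a stated time of 74 h (on this read-out higher numbers stand for weaker inhibition and lower numbers for stronger inhibition), compound 1 gives > 10000 nM, which is a limit of the assay and not a number. Going by the values given here, its standing therefore cannot be placed more exactly, and the only other compound measured, compound 2, offers no number either: the evidence consists of the limit of > 10000 nM in this assay, at which 2 of the 2 values shown sit.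

Compound 3 `O=C1C=CC2(C=C1)OCC(=O)N2S(=O)(=O)c1ccc(Br)s1` keeps the core of compound 1 and changes one group: 5-bromothiophen-2-yl in place of phenyl on a sulfonyl sulfur. In words, 5-bromothiophen-2-yl stands in place of phenyl on a sulfonyl sulfur.

Among the compounds with values here, only one measured step bears on this change, a step that the two limits leave unreadable from compound 1 to compound 2. It gives no size to carry over, and it alters a different feature of the molecule. No size or direction of step can thus be derived from the data, and the expectation stays close to the limit, with another limit about as likely as a number. For compound 3 the expected value is 7000 nM, with an estimated range from 500 nM to 20000 nM. This estimate amounts to an expected at least 1.4-fold lower number from compound 1 to compound 3 (0.15 log units; that floor lies within the scatter).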

Compound 3, half-maximal inhibitory concentration: > 10000 nM
Compound 3 ended at the assay's limit; the forecaster's own chance of this, stated with the estimate: 50%; middle value at least 1.4-fold (0.15 log units) away from the limit.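

Like compound 1 and compound 2, compound 3 gives a limit of the assay and not a number, so no step can be read between compound 1 and compound 3 in this assay: the limit of > 10000 nM in this assay, at which 3 of the 3 values shown sit. The compounds shown leave open how compound 1, compound 2 and compound 3 rank against one another, and which group on the sulfonyl sulfur would give a readable number.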